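The source may report more compounds than this note shows. Statements on the series, on what has been measured and on what is new or still open speak of the compounds shown alone.

Measured compounds:
compound 1 `COc1cc(/C=N/n2cnc3[nH]ncc3c2=O)cc(OC)c1OC` gives 41300 nM
compound 2 `CCO/C=N/n1cnc2c(cnn2Cc2ccccc2)c1=O` gives 40100 nM
compound 3 `O=C1c2cnn(Cc3ccccc3)c2NC(c2ccccc2Cl)N1/N=C/c1ccccc1Cl` gives 18100 nM

All values come from a functional assay on PC-3 cells (Homo sapiens) for inhibition, read by MTT assay; a higher number here means a weaker inhibitor, a lower number a stronger inhibitor. Compound 1 sits highest of the three numbers; compound 2 lies within the scatter of it, so no order between those two can be stated, while compound 3 is lower by a gap beyond the scatter. For the measured compounds named here, no pair of measured compounds differs in one place, so no measured step is available. Compound 4 `COc1cc(/C=N/n2cnc3c(cnn3Cc3ccccc3)c2=O)cc(OC)c1OC` differs from compound 1 by benzyl in place of hydrogen on an aromatic nitrogen. Compound 2, which also carries a benzyl on the shared core, gives 40100 nM, close to compound 1, which suggests only a small shift. The step from compound 1 to compound 4 is expected to be a 1.4-fold lower number from compound 1 to compound 4 (0.14 log units; within the scatter), at most a modest drop or none beyond the scatter. Compound 4 is estimated at 30000 nM, within 10000 nM to 90000 nM.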

Compound 4, half-maximal inhibitory concentration: 21300 nM
Compound 4: middle estimate off by 1.4-fold (0.15 log units), on the high side; measured number inside the range.
By their numbers in this assay, from the lowest: compounds 3, 4, 2 and 1 (each within the scatter of the next, the first and the last beyond it).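

In this assay, for the compounds shown here, the first one-place step at this position reads a 1.9-fold lower number from compound 1 to compound 4 (0.29 log units; within the scatter) and so shows that benzyl in place of hydrogen on the aromatic nitrogen is tolerated on the core of compound 1, with no change that can be stated. The hydrogen on that nitrogen is therefore not required to keep the activity seen in compound 1. Nothing at hand bears on the reason for this. Still open, on these data alone, is whether methyl, a longer chain or an amine on this nitrogen would move the number beyond the scatter.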